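Notes on an N-substituent step and Vero cytotoxicity

The source may hold more compounds than are shown below. What is called first, only, known or untested is meant among the compounds shown, and "the series" means these compounds.

Measured so far in an ADME assay on Vero cells (Chlorocebus sabaeus) for cytotoxicity, read by resazurin assay, with a stated time of 72 h; on this read-out lower numbers stand for higher toxicity in this test and higher numbers for lower toxicity in this test
- compound 1 `CC(=O)OC[C@H]1O[C@@H](CC(=O)CC2(O)C(=O)N(Cc3ccccc3)c3ccccc32)[C@H](OC(C)=O)[C@@H](OC(C)=O)[C@@H]1OC(C)=O` gives "not determined" (no result reported)
- compound 2 `CCCN1C(=O)/C(=C\C(=O)C[C@@H]2O[C@H](COC(C)=O)[C@@H](OC(C)=O)[C@H](OC(C)=O)[C@H]2OC(C)=O)c2ccccc21` gives 125000 nM

Going by the values given here, compound 2, at 125000 nM, holds the only number. Among the compounds with values here, compound 1 has no result, so compound 2 cannot be ranked against anything, and no measured step is available to set a scale for changes at any position.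

The next compound is compound 3 `CC(=O)OC[C@H]1O[C@@H](CC(=O)/C=C2\C(=O)N(Cc3cccc(C)c3)c3ccccc32)[C@H](OC(C)=O)[C@@H](OC(C)=O)[C@@H]1OC(C)=O`. Its difference from compound 2 is 3-methylphenyl in place of ethyl on a saturated chain carbon bound to an amide-type nitrogen in a ring. In words, this is 3-methylphenyl in place of ethyl on a saturated chain carbon bound to an amide-type nitrogen in a ring. Cut one bond further out, it reads propyl to 3-methylbenzyl. The rest of the structure is unchanged.

Within the data shown here, with no step to lean on, the expectation in this assay is only a judgement from this single structural change. A modest move toward lower numbers is expected, and a result within the scatter of compound 2 would not be surprising. The expected step is a 1.9-fold lower number from compound 2 to compound 3 (0.28 log units; within the scatter). For compound 3 the estimated value is 65000 nM, with an expected range of 18000 nM to 200000 nM.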

Compound 3, half-maximal cytotoxic concentration: 72500 nM
For compound 3 the middle estimate is 1.1-fold (0.05 log units) below the measured one; the measured number falls inside the stated range.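

In this assay, going by these compounds alone, placing 3-methylphenyl in place of ethyl on a saturated chain carbon bound to an amide-type nitrogen in a ring gives a 1.7-fold lower number from compound 2 to compound 3 (0.24 log units; within the scatter) as the first measured step and the first scale for any change at this position. The same difference, read as propyl to 3-methylbenzyl, adds one six-membered aromatic ring of carbon only and brings 7 heavy atoms in where 2 leave, yet this single step does not separate the two compounds in this test. No measured information on any property of these compounds bears on this result.

A single step at one position cannot show whether the read-out at this place is insensitive to the group in general or only to this pair, and compound 1 adds no number to the comparison. Still open, on these data alone, is how this assay responds when this position carries a basic amine such as a dimethylaminoethyl group, a carboxylic acid, or a longer chain such as octyl, with the rest of the shared core held constant.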